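A few compounds are considered here, and "the series" means these few. Any claim that something is new, unique, unknown or untested is made for them only; others in the source may bear on it.

In a functional assay for antagonist activity at transient receptor potential cation channel subfamily V member 1 (Homo sapiens), read by FLIPR (a lower number here means a stronger inhibitor, a higher number a weaker inhibitor), three compounds of one amide series have been measured. Compound 1 `Cc1cccnc1-c1ccc(C(=O)Nc2ccc(C(C)C)cc2)cc1` gives 73 nM. Compound 2 `Cc1cccnc1-c1ccc(C(=O)Nc2ccc(F)cc2)cc1` returns only a limit of the assay, > 4000 nM. Compound 3 `CC(C)(C)c1ccc(NC(=O)c2ccc(-c3ncccc3C#N)cc2)cc1` gives 30 nM, the lowest of the two numbers shown; its nearest neighbour is compound 1. The remaining entry, that of compound 2, is the limit described as the limit of > 4000 nM in this assay, at which 1 of the 3 values shown sits.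

Among the measured compounds shown here, the only step measured between two compounds that differ in one place is an at least 54-fold higher number from compound 1 to compound 2 (1.73 log units; beyond the scatter), a large change, but it concerns the group on the anilide ring and says nothing about the other end of the shared core.

Compound 4 `CC(C)(C)c1ccc(NC(=O)c2ccc(-c3ncccc3NS(=O)(=O)c3ccccc3)cc2)cc1` differs from compound 3 by (phenylsulfonyl)amino in place of cyano on an aromatic carbon, placed on an aromatic carbon of a six-membered aromatic ring with 1 nitrogen, ortho to a large group, two atoms from the ring nitrogen. For the measured compounds named here, no measured step touches this position, so there is no direct guide for its size or direction. The expected step of a 5.0-fold higher number from compound 3 to compound 4 (0.70 log units; beyond the scatter) is therefore set modest and drawn with a wide range. Compound 4 is expected to give about 150 nM, within a range from 20 nM to 1500 nM.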

Compound 4, half-maximal inhibitory concentration: 91 nM
Compound 4: middle estimate off by 1.6-fold (0.22 log units), on the high side; measured number inside the range.
By their numbers in this assay, from the lowest: compound 3; then compounds 1 and 4 (each within the scatter of the next). At a limit, above all of these: compound 2.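

In this assay the position on the six-membered aromatic ring with 1 nitrogen, ortho to a large group and two atoms from the ring nitrogen, now has a measured step of its own: a 3.0-fold higher number from compound 3 to compound 4 (0.48 log units; beyond the scatter). Going from cyano, with 2 heavy atoms, to (phenylsulfonyl)amino, with 10 heavy atoms, a further six-membered aromatic ring and a hydrogen-bond donor, costs only this modest step, so at this position a much larger group still leaves compound 4 at 91 nM in this assay. Nothing measured in the data shown accounts for the size or direction of this step.

What a plain amino group or a methylsulfonylamino group would give at this position stays open, so the compounds shown cannot tell whether the step goes with the sulfonyl link or with the phenyl ring it carries. Also open, going by these compounds, is whether a step of this size would hold with another group on the anilide ring, such as the isopropyl of compound 1, in place of the tert-butyl shared by compound 3 and compound 4.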